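Cytotoxicity notes: benzothiazolyl in place of phenyl

A few compounds are considered here, and "the series" means these few. Any claim that something is new, unique, unknown or untested is made for them only; others in the source may bear on it.

In an ADME assay on BJ cells (Homo sapiens) for cytotoxicity, with a stated time of 72 h (on this read-out lower numbers stand for an effect already at smaller amounts and higher numbers for an effect only at larger amounts of compound), compound 1 `O=C(Nc1nc(-c2cccc(F)c2)cs1)c1cc([N+](=O)[O-])ccc1Cl` gives 24000 nM and compound 2 `O=C(Nc1cc(C(F)(F)F)cc(C(F)(F)F)c1)c1cc([N+](=O)[O-])ccc1Cl` gives 22000 nM; the two values lie within the usual scatter of each other. Compound 3 `O=C(Nc1ccc(-c2ccccc2)cc1)c1cc([N+](=O)[O-])ccc1Cl` reaches only a limit of this assay, > 27000 nM. This places compound 3 at the limit of > 27000 nM in this assay, at which 1 of the 3 values shown sits, so no number stands to set against compound 1 or compound 2. Compound 4 `O=C(Nc1ccc(-c2nc3ccccc3s2)cc1)c1cc([N+](=O)[O-])ccc1Cl` differs from compound 3 in one place: 1,3-benzothiazol-2-yl in place of phenyl on an aromatic carbon. Going by the values given here, no step between measured compounds that differ in one place is available, so no size can be carried over. The step of an at least 1.0-fold lower number from compound 3 to compound 4 (0.01 log units; that floor lies within the scatter) is expected to be none beyond the scatter, with the value probably again at a limit of this assay. Compound 4 is estimated at 26000 nM, in the range 12000 nM to 45000 nM.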

Compound 4, half-maximal effective concentration: > 27000 nM
Compound 4: only a limit was reported; the forecaster's own chance of this, stated with the estimate: 60%; middle value at least 1.0-fold (0.01 log units) from the limit.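

No step can be read from compound 3 to compound 4, since each stands only at a limit of this assay: the limit of > 27000 nM in this assay, at which 2 of the 4 values shown sit.

Left open is whether 1,3-benzothiazol-2-yl in place of phenyl shifts this read-out at all.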